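The compounds below may be only part of what the source reports. "The series", "measured", "known", "first", "only" and "open" are said of these compounds alone.

Measured compounds in the series:

compound 1, `CC(=O)SCCC(CCCCC(=O)Nc1ccccc1)SC(C)=O` — 8.33%
compound 2, `CC(=O)SCCC(CCCCC(=O)Nc1ccccc1Cl)SC(C)=O` — 2.48%
compound 3, `O=C(CCCCC(CCSC(=O)c1ccccc1)SC(=O)c1ccccc1)Nc1ccccc1` — 3.12%

All three were read in a functional assay on HO8910 cells (Homo sapiens) for inhibition, read by MTT assay, with a stated time of 24 h, tested at 0.1 ug/mL; a lower number here means less inhibition of growth, a higher number more inhibition of growth at the concentration tested. In this assay compound 1 gives 8.33%, compound 2 gives 2.48% and compound 3 gives 3.12%; none of the three stands apart from the others once the usual scatter is allowed for.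

One single-point change is present twice in the set. Between compound 1 and compound 2 it reads (chloro in place of hydrogen on an aromatic carbon), and in this assay it made a step of a number 5.9 percentage points lower from compound 1 to compound 2 (within the scatter), which is within the scatter. Compound 3 carries a different core; its difference from compound 1 is not broken down here.

Compound 4, `O=C(CCCCC(CCSC(=O)c1ccccc1)SC(=O)c1ccccc1)Nc1ccccc1Cl`, is not yet measured. It differs from compound 3 by chloro in place of hydrogen on an aromatic carbon, the same change that turns compound 1 into compound 2, at a place described in the same words.

On that single precedent, the step from compound 3 to compound 4 in this assay is expected to be small, of about the size seen before: a number 1.1 percentage points lower from compound 3 to compound 4 (within the scatter) is the estimated step, resting on a number 5.9 percentage points lower from compound 1 to compound 2 (within the scatter). Compound 4 is therefore estimated at 2% in this assay, with a likely range of -5% to 10%; this rests on the value of compound 3, 3.12%, and on the earlier step, since a number much below that of compound 3 would leave little room downward.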

Compound 4, percent growth inhibition at one concentration: "not active" (no number reported)
The entry for compound 4 holds no number; there is nothing to compare the estimate with.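

Within the data shown here, compound 4 is entered in this assay as "not active", with no number, so no step from compound 3 to compound 4 can be read. No measured evidence bears on this result. The compounds shown leave open how chloro in place of hydrogen on the aromatic carbon acts on the core of compound 3 in numerical terms, and whether its effect there matches that on the core of compound 1.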